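Cytotoxicity notes on the diaryl ether series, compound 4

A few compounds are considered here, and "the series" means these few. Any claim that something is new, unique, unknown or untested is made for them only; others in the source may bear on it.

Measured compounds:
compound 1 `Cc1cc(/C=C/C#N)cc(C)c1Oc1nc(Nc2ccc(CN3CCNCC3)cc2)nc2ccsc12` — in an ADME assay on MT4 cells (Homo sapiens) for cytotoxicity, read by MTT assay, with a stated time of 5 days (on this read-out higher numbers stand for lower toxicity in this test and lower numbers for higher toxicity in this test), compound 1 gives 3970 nM
compound 2 `Cc1cc(/C=C/C#N)cc(C)c1Oc1nc(Nc2ccc(N3CCCC(N)C3)cc2)nc2sccc12` — compound 2 gives 4610 nM
compound 3 `Cc1cc(/C=C/C#N)cc(C)c1Oc1nc(Nc2ccc(CN3CCNCC3)cc2)nc2sccc12` — compound 3 gives 4030 nM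

Compound 1 shows the lowest of the three numbers in this assay, but all three sit together: compound 3 is the nearest, and even compound 2, the furthest, lies within the scatter of compound 1, so no order among them is claimed. Among the compounds with values here, the single step between measured compounds differing in one place, a 1.1-fold lower number from compound 2 to compound 3 (0.06 log units; within the scatter), exchanges 3-aminopiperidin-1-yl for (piperazin-1-yl)methyl on an aromatic carbon and stays within the scatter.

Compound 4 `Cc1cc(/C=C/C#N)cc(C)c1Oc1nc(Nc2ccc(N3CCCC(NS(C)(=O)=O)C3)cc2)nc2ccsc12` carries the change (3-(methanesulfonamido)piperidin-1-yl in place of (piperazin-1-yl)methyl on an aromatic carbon). This runs in the opposite sense to the measured step: (piperazin-1-yl)methyl again gives way to a piperidine, here one bearing the methanesulfonamido group rather than the amino group of compound 2. Within the data shown here, because a 1.1-fold lower number from compound 2 to compound 3 (0.06 log units; within the scatter) showed no movement beyond the scatter for the related exchange, and no measured compound carries a methanesulfonamido group, the expected step is a 1.1-fold higher number from compound 1 to compound 4 (0.05 log units; within the scatter), within the scatter. Compound 4 is therefore estimated at 4500 nM, with a range of 2000 nM to 10000 nM.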

Compound 4, half-maximal cytotoxic concentration: > 217000 nM
Compound 4 gave a limit, no number (the forecaster's own chance of this, stated with the estimate: 15%); at least 48-fold (1.68 log units) between middle value and limit.
By their numbers in this assay, from the lowest: compounds 1, 3 and 2 (each within the scatter of the next). At a limit, above all of these: compound 4.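

In this assay, compound 4 gives a limit and not a number: the limit of > 217000 nM in this assay, at which 1 of the 4 values shown sits.

The exchange on the aromatic carbon, para to a large group, gives an at least 54-fold higher number from compound 1 to compound 4 (1.73 log units; beyond the scatter). The earlier step at this place, a 1.1-fold lower number from compound 2 to compound 3 (0.06 log units; within the scatter), left open whether any change here could move this read-out beyond the scatter, and the new step shows that one can. With the core of compound 1 unchanged, this step belongs to a single exchange, 3-(methanesulfonamido)piperidin-1-yl in place of (piperazin-1-yl)methyl, so the shift in the read-out is tied to this one place in the structure.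

The compounds shown do not separate the contribution of the piperidine ring from that of the methanesulfonamido group, since that exchange alters both at once. A comparison on the core of compound 1 with a free amine or an acetamido group at the same piperidine carbon would address this, and a carboxylic acid there would test whether the step is specific to the sulfonamide.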